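The source may hold more compounds than are shown below. What is called first, only, known or untested is meant among the compounds shown, and "the series" means these compounds.

Three related compounds have so far been tested in a functional assay on KB cells (Homo sapiens) for cytotoxicity, read by sulforhodamine B assay, with a stated time of 48 h; on this read-out higher numbers stand for weaker inhibition and lower numbers for stronger inhibition. Compound 1 `CCC(C)c1cc(/C=C/C(=O)c2ccccc2)cc2cc(C(=O)OC)c(=O)oc12` gives 13400 nM in this assay. Compound 2 `CCOC(=O)c1cc2cc(/C=C/C(=O)c3ccccc3)cc(C(C)CC)c2oc1=O` gives 10500 nM, and compound 3 `CCOC(=O)c1cc2cc(/C=C/C(=O)c3ccc(Cl)cc3)cc(C(C)CC)c2oc1=O` gives 14300 nM. All three numbers lie close together, and neither of the two single-point changes among them moves the read-out beyond the usual scatter of repeated measurements.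

The difference between compound 2 and compound 1 is hydrogen in place of methyl on a saturated chain carbon bound to an oxygen next to a carbonyl group, and the step it made was a 1.3-fold higher number from compound 2 to compound 1 (0.11 log units; within the scatter). The difference between compound 2 and compound 3 is chloro in place of hydrogen on an aromatic carbon, with a step of a 1.4-fold higher number from compound 2 to compound 3 (0.13 log units; within the scatter).

Compound 4 `CCC(C)c1cc(/C=C/C(=O)c2ccc(Cl)cc2)cc2cc(C(=O)OC)c(=O)oc12` has not yet been measured. It differs from compound 3 by hydrogen in place of methyl on a saturated chain carbon bound to an oxygen next to a carbonyl group, which is the same change already seen from compound 2 to compound 1, made here on the core of compound 3 rather than that of compound 2; the two cores differ by the chloro group described above. Because the earlier step was a 1.3-fold higher number from compound 2 to compound 1 (0.11 log units; within the scatter), the step from compound 3 to compound 4 is expected to be of similar small size, estimated as a 1.2-fold higher number from compound 3 to compound 4 (0.08 log units; within the scatter). On that basis compound 4 is expected to give about 17000 nM in this assay, with a plausible range from 8500 nM to 34000 nM.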

Compound 4, half-maximal inhibitory concentration: 28300 nM
Beside the measured number, compound 4's estimate is 1.7-fold (0.22 log units) below it; the measured number falls inside the stated range.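

Exchanging ethoxycarbonyl for methoxycarbonyl on the chloro-bearing core gives, in this assay, a 2.0-fold higher number from compound 3 to compound 4 (0.30 log units; within the scatter), and this agrees with the same exchange on the core without chloro: the same change on two cores in this assay, a 1.3-fold higher number (0.11 log units; within the scatter) from compound 2 to compound 1 and a 2.0-fold higher number (0.30 log units; within the scatter) from compound 3 to compound 4, 1.6-fold (0.19 log units) apart, within the scatter of two such steps. Seen the other way, putting chloro in place of hydrogen on an aromatic carbon gives a 2.1-fold higher number from compound 1 to compound 4 (0.32 log units; beyond the scatter), a modest step and the only one here beyond the scatter, yet it cannot be told apart from the same change made on the core with ethoxycarbonyl: the same change on two cores in this assay, a 1.4-fold higher number (0.13 log units; within the scatter) from compound 2 to compound 3 and a 2.1-fold higher number (0.32 log units; beyond the scatter) from compound 1 to compound 4, 1.6-fold (0.19 log units) apart, within the scatter of two such steps. Each change therefore carries from one core to the other in this small set without a detectable difference, but this rests on just two closely related cores and on small steps, so it does not show that the two changes would combine the same way on a more distant core, and it says nothing about why the numbers move.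

The compounds shown leave open how the read-out would respond if a carboxylic acid, an amide or a longer chain such as butoxycarbonyl took the place of the ethoxycarbonyl group. They also leave open whether fluoro, methoxy or an amine in place of chloro would give a larger step than any seen so far.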